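The compounds below may be only part of what the source reports. "The series", "measured", "known", "first", "only" and "open" are said of these compounds alone.

Measured in a functional assay on V79-379A cells (Cricetulus griseus) for cytotoxicity, read by MTT assay, in the presence of a further agent that is not named here; a lower number here means a stronger inhibitor, a higher number a weaker inhibitor:
- compound 1 `COC1=CC(=O)c2c(c(COC(C)=O)c(C)n2C)C1=O`: 2500 nM
- compound 2 `COC1=CC(=O)c2c(c(COc3ccccc3)c(C)n2C)C1=O`: 700 nM
- compound 3 `COC1=CC(=O)c2c(c(Cc3cc(F)ccc3O)c(C)n2C)C1=O`: 110000 nM

Compound 3 is the weakest inhibitor of these three in this assay. Two measured steps show how far it lies from the others: a 44-fold higher number from compound 1 to compound 3 (1.64 log units; beyond the scatter), and a 160-fold higher number from compound 2 to compound 3 (2.20 log units; beyond the scatter). Both are large, and both replace an oxygen-linked group with 5-fluoro-2-hydroxyphenyl on a saturated chain carbon bound to an aromatic carbon. The remaining step, a 3.6-fold lower number from compound 1 to compound 2 (0.55 log units; beyond the scatter), is modest and changes only the group on the oxygen.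

Compound 4 `COC1=CC(=O)c2c(c(Cc3ccc(O)c(F)c3)c(C)n2C)C1=O` has the same atoms as compound 3, joined differently: 3-fluoro-4-hydroxyphenyl in place of 5-fluoro-2-hydroxyphenyl on a saturated chain carbon bound to an aromatic carbon. Among the compounds with values here, no measured pair shows what such a swap does, so the evidence is indirect. Compound 4 still has a hydroxyphenyl group carrying fluorine at the place where the large steps arose, so it is expected to remain close to compound 3 at 110000 nM.

No change beyond the scatter is expected, and the estimated change is a 1.8-fold lower number from compound 3 to compound 4 (0.26 log units; within the scatter). For compound 4 the estimate is 60000 nM, with an expected range of 15000 nM to 200000 nM.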

Compound 4, half-maximal inhibitory concentration: 280000 nM
Compound 4: middle estimate off by 4.7-fold (0.67 log units), on the low side, and the stated range ends below it.
By their numbers in this assay, from the lowest: compound 2; then compound 1; then compound 3; then compound 4.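

With the atoms unchanged and only their arrangement different, the aromatic group on this saturated chain carbon still matters in this assay: 3-fluoro-4-hydroxyphenyl in place of 5-fluoro-2-hydroxyphenyl gives a 2.5-fold higher number from compound 3 to compound 4 (0.41 log units; beyond the scatter). The number therefore does not depend only on a fluorinated hydroxyphenyl group being present, as the arrangement of that group moves it further, though modestly. Against the groups joined through oxygen, the gap grows to a 400-fold higher number from compound 2 to compound 4 (2.60 log units; beyond the scatter) and a 110-fold higher number from compound 1 to compound 4 (2.05 log units; beyond the scatter), which makes compound 4 the weakest inhibitor of the four.

No measurement offered here explains why the two arrangements differ. Also open, as far as these compounds go, is whether the hydroxyl or the fluorine matters more for these numbers, and how an amine or a carboxylic acid would behave at this place.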